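This account rests on a few compounds, and the source may have more. Where it says the series, first, only, none or still open, it means among the compounds named here.

Working notes on the series. Compound 1 `CCCCOc1ccc(C(=O)Nc2cc3ccc(OC4CCN(C)CC4)c(C)c3oc2=O)cc1CC=C(C)C`, compound 2 `C#CCOc1ccc(C(=O)Nc2cc3ccc(OC4CCN(C)CC4)c(C)c3oc2=O)cc1CC=C(C)C` and compound 3 `CC(C)=CCc1cccc(C(=O)Nc2cc3ccc(OC4CCN(C)CC4)c(C)c3oc2=O)c1` share one core and differ only at a single aromatic carbon. In a functional assay on MCF7 cells (Homo sapiens) for antiproliferative activity (on this read-out higher numbers stand for weaker inhibition and lower numbers for stronger inhibition), compound 1 gives 1440 nM, compound 2 gives 1120 nM and compound 3 gives 2100 nM. Compound 3 thus holds the highest of the three numbers, but the steps leading to it are a 1.5-fold higher number from compound 1 to compound 3 (0.16 log units; within the scatter) and a 1.9-fold higher number from compound 2 to compound 3 (0.27 log units; within the scatter), so none of the three is separated from the others beyond the scatter.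

Compound 4 `CC(C)=CCc1cc(C(=O)Nc2cc3ccc(OC4CCN(C)CC4)c(C)c3oc2=O)ccc1OC1CCN(C)CC1` has not yet been measured. It differs from compound 3 in one place: (1-methylpiperidin-4-yl)oxy in place of hydrogen on an aromatic carbon. The two measured steps that bear on this change are those at the same aromatic carbon, where hydrogen replaces butoxy, a 1.5-fold higher number from compound 1 to compound 3 (0.16 log units; within the scatter), and where hydrogen replaces propargyloxy, a 1.9-fold higher number from compound 2 to compound 3 (0.27 log units; within the scatter); both lie within the scatter, and both have the compound carrying the group at that carbon giving the lower number. No larger group at that carbon has been measured, so nothing supports a step beyond the scatter.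

Compound 4 is therefore expected to give 1200 nM in this assay, with a range from 450 nM to 3200 nM. The expected step is a 1.8-fold lower number from compound 3 to compound 4 (0.24 log units; within the scatter), a shift no larger than the scatter.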

Compound 4, half-maximal inhibitory concentration: 470 nM
For compound 4 the middle estimate is 2.6-fold (0.41 log units) above the measured one; low and high end bracket the measured number.
By their numbers in this assay, from the lowest: compound 4; then compounds 2, 1 and 3 (each within the scatter of the next).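

For the compounds shown here, at the aromatic carbon para to a large group and ortho to the 3-methylbut-2-en-1-yl group, (1-methylpiperidin-4-yl)oxy gives the first step beyond the scatter in this assay (a 4.5-fold lower number from compound 3 to compound 4 (0.65 log units; beyond the scatter)), a modest one, where the ethers of compounds 1 and 2 stayed within the scatter of hydrogen. The same separation appears at the oxygen itself: 1-methylpiperidin-4-yl stands apart from propargyl (a 2.4-fold lower number from compound 2 to compound 4 (0.38 log units; beyond the scatter)) and from butyl (a 3.1-fold lower number from compound 1 to compound 4 (0.49 log units; beyond the scatter)), while propargyl and butyl remain within the scatter of each other (a 1.3-fold lower number from compound 1 to compound 2 (0.11 log units; within the scatter)), so this position responds to the choice of group on that oxygen and not merely to the presence of an ether. Nothing available explains this step.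

The compounds shown do not separate the contribution of the ring nitrogen from that of the ring itself, a question that a cyclohexyloxy group or an open-chain 2-(dimethylamino)ethoxy group at the same carbon would address. They also leave open whether the step persists without the 3-methylbut-2-en-1-yl group, or with a piperidin-4-yloxy group lacking the methyl on nitrogen.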